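Ether side chain: from compound 3 to compound 4

This account rests on a few compounds, and the source may have more. Where it says the series, first, only, none or still open, it means among the compounds named here.

- compound 1 `CCOC(=O)N1[C@@H]2C=C[C@@](OC)(C(=O)c3c2cc(OC)c(OC)c3OCc2ccc(F)cc2)N1C(=O)OCC` gives 51.8 ug/mL as a measured number
- compound 2 `COC(=O)N1[C@@H]2C=C[C@@](OC)(C(=O)c3c2cc(OC)c(OC)c3OCc2ccccc2)N1C(=O)OC` gives > 300 ug/mL as a limit
- compound 3 `CCCOc1c(OC)c(OC)cc2c1C(=O)[C@]1(OC)C=C[C@H]2N(C(=O)OCC)N1C(=O)OCC` gives > 300 ug/mL as a limit

Compound 3 has no number in an ADME assay on KB cells (Homo sapiens) for cytotoxicity (a higher number here means that more compound is needed for the effect, a lower number that less compound is needed), and stands at the limit of > 300 ug/mL in this assay, at which 2 of the 3 values shown sit, with no value to fix its true position.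

The change to compound 4 `CCOC(=O)N1[C@@H]2C=C[C@@](OC)(C(=O)c3c2cc(OC)c(OC)c3OCc2ccc(Cl)cc2)N1C(=O)OCC` reads 4-chlorophenyl in place of ethyl on a saturated chain carbon bound to an oxygen on an aromatic ring and puts 4-chlorophenyl in place of ethyl on a saturated chain carbon bound to an oxygen on an aromatic ring. Among the measured compounds shown here, one measured step bears on this place. It is an at least 5.7-fold higher number from compound 1 to compound 3 (0.76 log units; beyond the scatter) and it lies beyond the scatter, with ethyl in place of 4-fluorophenyl. Read in reverse, with 4-chlorophenyl standing in for 4-fluorophenyl, it points to a lower number in this assay of at least modest size. Compound 1 at 51.8 ug/mL is the nearest anchor for that expectation.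

Compound 2 urges caution, since it also has an aromatic ring on that chain carbon. Its result is only a limit, so compound 4 could also end at a limit.

The expected size is an at least 6.0-fold lower number from compound 3 to compound 4 (0.77 log units; beyond the scatter) as an estimate. Compound 4 is expected at 50 ug/mL with an estimated range of 15 ug/mL to 170 ug/mL in this series.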

Compound 4, concentration for half-maximal effect: 99.9 ug/mL
Estimate against measurement, compound 4: 2.0-fold (0.30 log units) below, within the range that was stated.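

In this assay, the gain seen with a 4-fluorophenyl group on this saturated chain carbon also appears with 4-chlorophenyl in place of ethyl: an at least 3.0-fold lower number from compound 3 to compound 4 (0.47 log units; beyond the scatter), so the effect of replacing ethyl at this position is not confined to the fluoro compound. Exchanging the halogen on the aromatic ring gives a 1.9-fold higher number from compound 1 to compound 4 (0.29 log units; within the scatter), which stays within the scatter, so chloro and fluoro cannot be told apart at this position in this assay. The step from ethyl remains open-ended in size, since compound 3 carries a limit rather than a number: the limit of > 300 ug/mL in this assay, at which 2 of the 4 values shown sit.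

Compound 2 also has an aromatic ring on this chain carbon but differs from compound 4 in more than one place, so the compounds shown do not separate the contribution of the aromatic ring from that of its halogen. Going by these compounds, it also remains open whether a 4-methoxyphenyl group, a 4-aminophenyl group or a longer chain such as butyl on this carbon would keep the number near those of compound 1 and compound 4 or return it to the limit.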